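Efficacy notes on a tertiary-amine variant of compound 1

The source may hold more compounds than are shown below. What is called first, only, known or untested is meant among the compounds shown, and "the series" means these compounds.

Measured compounds:
compound 1 `CC(C)c1onc(-c2c(Cl)cccc2Cl)c1COc1ccc(N(C)C(=O)c2ccc(C(=O)O)cc2)c(C(F)(F)F)n1`, 101%
compound 2 `Cc1cc(OCc2c(-c3c(Cl)cccc3Cl)noc2C(C)C)nc2ccccc12`, 104%
compound 3 `Cc1cc(C(F)(F)F)cc(OCc2c(-c3c(Cl)cccc3Cl)noc2C(C)C)n1`, 98%

In an assay on isolated protein for agonist activity at Bile acid receptor (Homo sapiens), read by FRET (on this read-out higher numbers stand for larger maximal responses and lower numbers for smaller maximal responses), compound 1 stands second of the three numbers. Compound 2 lies a few points higher and compound 3 a few points lower, and both gaps are within the usual scatter, so the three compounds are indistinguishable on this read-out: all reach the maximal response of the reference.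

Compound 4 `CC(C)c1onc(-c2c(Cl)cccc2Cl)c1COc1ccc(N(C)Cc2cccc(C(=O)O)c2)c(C(F)(F)F)n1` is not yet measured. The change from compound 1: 3-carboxybenzyl in place of (4-carboxyphenyl)carbonyl on a nitrogen on an aromatic ring

Going by the values given here, no step between measured compounds is available, so no size can be inferred from the series. The three measured compounds all sit at full response, and the expectation is a step from compound 1 to compound 4 of a number 11 percentage points lower from compound 1 to compound 4 (beyond the scatter) in this assay, a small loss at most, probably not beyond the scatter. Compound 4 is expected to give about 90%, estimated between 60% and 112%.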

Compound 4, largest response reached (reported as efficacy), in percent of the reference or control that the assay uses: 102%
Estimate against measurement, compound 4: 12 percentage points below; the range from low to high includes it.
By their numbers in this assay, from the lowest: compounds 3, 1, 4 and 2 (each within the scatter of the next).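

In this assay, 3-carboxybenzyl in place of (4-carboxyphenyl)carbonyl on a nitrogen on an aromatic ring gives a step of a number 1 percentage points higher from compound 1 to compound 4 (within the scatter). This position therefore keeps full response without the carbonyl attached to that nitrogen, at least with this carboxybenzyl group. No supporting data bear on why this response is retained.

The change alters both the link and the place of the carboxylic acid, and the compounds shown do not separate the two. On these data alone, whether 4-carboxybenzyl or plain benzyl keeps this response remains open.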